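Swapping a Pyrazole Link on a Shared Fused Core

The compounds below may be only part of what the source reports. "The series", "measured", "known", "first", "only" and "open" are said of these compounds alone.

Three compounds that share the same left-hand fragment and core have been measured in a physicochemical assay for lipophilicity, using the shake flask method, in phosphate buffer, measured as octanol-water partition, with a stated time of 30 min, at pH 7.4; on this read-out higher numbers stand for higher lipophilicity and lower numbers for lower lipophilicity. Compound 1 `Cn1cc(-c2cnc(NCc3c(F)ccc4c3CCO4)c3cn[nH]c(=O)c23)cn1` gives 2.7, the highest of the three readings. Compound 3 `CN(C)Cc1ccc2c(c1)CN(c1cnc(NCc3c(F)ccc4c3CCO4)c3cn[nH]c(=O)c13)C2=O` gives 2.2, which sits below compound 1 by more than the usual scatter. Compound 2 `C[C@H]1CC(=O)N(c2cnc(NCc3c(F)ccc4c3CCO4)n3cnnc23)C1` gives 1.8, the lowest of the three, and it too lies further from compound 1 than the scatter allows. No pair among these three differs in only one place, so no single structural step can be read off from them.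

Compound 4 `CN(c1ccn(C)n1)c1cnc(NCc2c(F)ccc3c2CCO3)c2cn[nH]c(=O)c12` has not yet been measured. It differs from compound 1 in one place: methyl(1-methyl-1H-pyrazol-3-yl)amino in place of 1-methyl-1H-pyrazol-4-yl on an aromatic carbon. The group that leaves and the group that enters are both small, both built around a five-membered aromatic ring, and neither carries a hydrogen-bond donor. Among the compounds with values here, with no matching step among the measured compounds to lean on, the expected change is small: the step is estimated as a number 0.20 log units higher from compound 1 to compound 4 (within the scatter), within the usual scatter. Compound 4 is therefore expected to give about 2.9 in this assay, with a likely range from 2.3 to 3.5.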

Compound 4, distribution coefficient: 2.4
Compound 4: the middle estimate sits 0.50 log units above what was measured, and the stated range covers the measured number.
By their numbers in this assay, from the lowest: compound 2; then compounds 3, 4 and 1 (each within the scatter of the next, the first and the last beyond it).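

Placing methyl(1-methyl-1H-pyrazol-3-yl)amino in place of 1-methyl-1H-pyrazol-4-yl on an aromatic carbon gives the first step in this set that can be read at a single place: in this assay the result is a number 0.30 log units lower from compound 1 to compound 4 (within the scatter) for this one change. The entering group has 8 heavy atoms against 6 and 3 hydrogen-bond acceptors against 2, and it is joined to the shared core through an amino nitrogen rather than directly through the five-membered ring, yet this read-out does not separate the two compounds. No measurement shown here accounts for the result at this position.

As far as these compounds go, with a single pair to go on, it remains open whether other groups at this place would also stay within the scatter of compound 1, and this pair cannot show what the methyl on the linking nitrogen contributes on its own. A plain dimethylamino group, a carboxylic acid or a longer alkyl chain on the same aromatic carbon would test how far the number can move at this position.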